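The source may report more compounds than this note shows. Statements on the series, on what has been measured and on what is new or still open speak of the compounds shown alone.

Three amides sharing one core have been tested in a functional assay on PC-3 cells (Homo sapiens) for inhibition, read by MTT assay, with a stated time of 72 h; on this read-out higher numbers stand for weaker inhibition and lower numbers for stronger inhibition. Compound 1 `CC(C)n1ncc2c(C(=O)NCc3cn(Cc4ccc(C(F)(F)F)cc4)nn3)cccc21` gives 23900 nM. Compound 2 `CC(C)n1ncc2c(C(=O)NCc3cn(Cc4ccc(C#N)cc4)nn3)cccc21` gives 18200 nM. Compound 3 `COc1ccc(Cn2cc(CNC(=O)c3cccc4c3cnn4C(C)C)nn2)cc1` gives 34000 nM. On these three numbers compound 3 is separated from the others only by small steps: a 1.4-fold higher number from compound 1 to compound 3 (0.15 log units; within the scatter) and a 1.9-fold higher number from compound 2 to compound 3 (0.27 log units; within the scatter), so the three compounds cannot be told apart on this read-out. The remaining step, a 1.3-fold lower number from compound 1 to compound 2 (0.12 log units; within the scatter), is likewise small.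

Compound 4 `CC(C)n1ncc2c(C(=O)NCc3cn(Cc4ccc(C(C)(C)C)cc4)nn3)cccc21` has not yet been measured in this assay. Its change from compound 3 is tert-butyl in place of methoxy on an aromatic carbon. Going by the values given here, the steps that bear on this change are those that move the same substituent: a 1.4-fold higher number from compound 1 to compound 3 (0.15 log units; within the scatter) and a 1.9-fold higher number from compound 2 to compound 3 (0.27 log units; within the scatter), both within the scatter, and the substituent that enters in compound 4 appears in none of the measured compounds. Among the compounds with values here, since every swap at this position so far has left the number essentially where it was, no step beyond the scatter is expected in this assay for compound 4, with an expected step of a 1.1-fold lower number from compound 3 to compound 4 (0.05 log units; within the scatter). The estimate for compound 4 in this assay is 30000 nM, with a range from 12000 nM to 75000 nM.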

Compound 4, half-maximal inhibitory concentration: 8890 nM
Compound 4: middle estimate off by 3.4-fold (0.53 log units), on the high side, outside the stated range (below it).
By their numbers in this assay, from the lowest: compound 4; then compounds 2, 1 and 3 (each within the scatter of the next).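

Compound 4 shows that the group at this position on the benzyl ring can change the number in this assay, which the three earlier compounds did not show: tert-butyl gives a modest step beyond the scatter against each of them (a 3.8-fold lower number from compound 3 to compound 4 (0.58 log units; beyond the scatter); a 2.0-fold lower number from compound 2 to compound 4 (0.31 log units; beyond the scatter); a 2.7-fold lower number from compound 1 to compound 4 (0.43 log units; beyond the scatter)). Methoxy, nitrile and trifluoromethyl could not be told apart, so compound 4 is the first to separate from the others, and it is the strongest inhibitor of the four on this read-out, though the steps are modest. No measurement bearing on why tert-butyl behaves differently from the other three groups is available.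

The four compounds leave open whether this step belongs to tert-butyl alone or would also appear with other carbon-only groups in the same place, such as isopropyl, cyclohexyl or a longer chain like n-butyl, and what a dimethylamino group or a carboxylic acid would do there. They also leave open whether the same order would hold on any cells other than those of this single assay.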